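A few compounds are considered here, and "the series" means these few. Any claim that something is new, unique, unknown or untested is made for them only; others in the source may bear on it.

Of the compounds shown here, two have been measured in an in vitro assay on BTI-TN-5B1-4 cells for inhibition of Amine oxidase [flavin-containing] B (Homo sapiens), read by fluorescence, with a stated time of 15 min, tested at 100 uM (a lower number here means less inhibition, a higher number more inhibition at the concentration tested (going by the name of the read-out)), before compound 3 is considered. Compound 1 `O=C(c1ccccc1)c1cc2cc(Br)ccc2oc1=O` was reported in this assay as "not active" (no number reported), with no number given. Compound 2 `O=C(c1ccccc1)c1cc2cc(Cl)cc(Br)c2oc1=O` gave in this assay 40%, and compound 2 therefore stands as the holder of the only number shown, the other entry being without one. Compound 3 `O=C(c1ccccc1)c1cc2cc(Br)cc(Br)c2oc1=O` is built from compound 2 by a single change: bromo in place of chloro on an aromatic carbon. Among the compounds with values here, no pair of measured compounds differs in one place, so there is no measured step to lean on; the expectation for this assay is a step of no real size, none beyond the scatter, in either direction. Compound 3 is thus expected to come out close to compound 2, with an estimated step of no change at the digits printed from compound 2 to compound 3 (within the scatter). In this assay compound 3 is estimated at 40%, within a range from 22% to 58%.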

Compound 3, a percentage reported as inhibition, at one concentration (the size of the read-out at that concentration, not a potency): 40%
Estimate against measurement, compound 3: no gap at the digits printed; measured number inside the range.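

In this assay, within the data shown here, the first comparison that differs in one place gives no change at the digits printed from compound 2 to compound 3 (within the scatter), for bromo in place of chloro on this aromatic carbon, which sits meta to a bromo group. Among these compounds, at this position, with that bromo group in place, the read-out therefore does not separate chloro from bromo at the single concentration tested, a point that the earlier compounds could not show. Nothing measured here offers an explanation for this result.

The compounds shown leave open whether an amine, a methoxy group or a carboxylic acid on this carbon would hold the inhibition at this level or shift it. They also leave open how compound 2 and compound 3 would compare as potencies, since this read-out is not a potency.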